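Shrinking the Ring Amine From Six to Five Members

The source may hold more compounds than are shown below. What is called first, only, known or untested is meant among the compounds shown, and "the series" means these compounds.

Compound 2 `COc1cc(/C=C/C(=O)Nc2ccccc2)ccc1OCCCCCN1CCCCC1` gives 1.65 in a physicochemical assay for lipophilicity, using the shake flask method, measured as octanol-water partition, at pH 7.4; a lower number here means a more polar compound, a higher number a more lipophilic compound. Compound 1 `COc1cc(/C=C/C(=O)Nc2ccccc2)ccc1OCCCCN(C)C` carries a dimethylamino group where compound 2 carries the ring amine. In this assay compound 1 gives 1.57, and the step of a number 0.08 log units higher from compound 1 to compound 2 (within the scatter) falls within the scatter, so the two numbers cannot be told apart. Compound 3 `COc1cc(/C=C/C(=O)Nc2ccccc2)ccc1OCCCCCN1CCCC1` carries the change (pyrrolidin-1-yl in place of piperidin-1-yl on a saturated chain carbon, five bonds along the chain from an oxygen on an aromatic ring). Going by the values given here, only the step from compound 1 to compound 2 bears on this: exchanging dimethylamino for a six-membered ring amine moved the number by an amount within the scatter. Trimming that ring from six to five members is a smaller structural change than that exchange, so compound 3 is expected to land close to compound 2, with an expected step of a number 0.15 log units lower from compound 2 to compound 3 (within the scatter) that stays within the scatter. The estimate for compound 3 is 1.5, with a range from 1.2 to 1.8.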

Compound 3, partition coefficient: 1.64
Compound 3: the middle estimate sits 0.14 log units below what was measured; measured number inside the range.
By their numbers in this assay, from the lowest: compounds 1, 3 and 2 (each within the scatter of the next).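

In this assay, going from the six-membered to the five-membered ring amine gives a number 0.01 log units lower from compound 2 to compound 3 (within the scatter) and so leaves no difference that can be read at this place, on a saturated chain carbon five bonds along the chain from an oxygen on an aromatic ring. Setting (pyrrolidin-1-yl)methyl in place of dimethylamino gives a number 0.07 log units higher from compound 1 to compound 3 (within the scatter) as well, so the open-chain amine and both ring amines now all lie within the scatter of one another, where earlier only one ring size could be compared with dimethylamino. Nothing at hand explains why these three amine groups read alike.

Still open, on these data alone, is whether a morpholine, with an oxygen in its ring, or a seven-membered azepane would read the same at this place. Also open, as far as these compounds go, is whether this agreement would hold with a longer chain or with a carboxylic acid in place of the amine.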